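Dropping the chloro from a weak hydrazone analogue

This account rests on a few compounds, and the source may have more. Where it says the series, first, only, none or still open, it means among the compounds named here.

Compound 1 `COc1ccc(OC)c(/C=C/c2nnc(Nc3ccc(Cl)cc3)o2)c1`: 6760 nM
Compound 2 `COc1ccc(OC)c(/C=C/C(=O)N/N=C/c2ccc(Cl)cc2)c1`: > 100000 nM

Both compounds were tested in a functional assay on OVCAR-4 cells (Homo sapiens) for antiproliferative activity, read by sulforhodamine B assay, with a stated time of 48 h; a lower number here means a stronger inhibitor of growth, a higher number a weaker inhibitor of growth. Compound 1 gives 6760 nM. Compound 2 gives > 100000 nM, which is a limit of the assay rather than a number; this is the limit of > 100000 nM in this assay, at which 1 of the 2 values shown sits, and it places compound 2 at the weak end of what the assay reports. Compound 3 `COc1ccc(OC)c(/C=C/C(=O)N/N=C/c2ccccc2)c1` is the next compound and has not yet been measured. It differs from compound 2 by hydrogen in place of chloro on an aromatic carbon. Among the measured compounds shown here, no measured step between two compounds isolates this change, so the size of the step is uncertain. Because compound 2 already stands at > 100000 nM, the expectation is that the step from compound 2 to compound 3 a step that the limit leaves unreadable from compound 2 to compound 3 stays within the scatter and compound 3 is likewise expected to reach only the limit. The estimate for compound 3 is 150000 nM, with a range from 40000 nM to 600000 nM.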

Compound 3, concentration for total growth inhibition: > 100000 nM
Compound 3: no number, only a limit (the forecaster's own chance of this, stated with the estimate: 80%); the middle value is on the limit's open side.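

No step from compound 2 to compound 3 can be read, because both compounds stand at a limit of the assay rather than at a number: the limit of > 100000 nM in this assay, at which 2 of the 3 values shown sit.

The compounds shown leave open whether going from 4-chlorophenyl to phenyl changes growth inhibition in this assay at all.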